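Aryl variation on the ring nitrogen of the shared core

The compounds below may be only part of what the source reports. "The series", "measured", "known", "first", "only" and "open" are said of these compounds alone.

compound 1 `COc1ccccc1N1C(=O)/C(=C/c2ccc(OCc3ccc(C(=O)O)cc3)cc2)SC1=S`: 2000 nM
compound 2 `COc1ccc(N2C(=O)/C(=C/c3ccc(OCc4ccc(C(=O)O)cc4)cc3)SC2=S)cc1`: > 10000 nM

In an assay on isolated protein for inhibition of Apoptosis regulator Bcl-2 (Homo sapiens), read by fluorescence polarization (on this read-out higher numbers stand for weaker inhibition and lower numbers for stronger inhibition), compound 1 gives 2000 nM. For compound 2 this assay reports only a limit, > 10000 nM, so no number is known for it; of the two values shown, this one sits at the limit of > 10000 nM in this assay, at which 1 of the 2 values shown sits. Within the data shown here, the one measured step, an at least 5.0-fold higher number from compound 1 to compound 2 (0.69 log units; beyond the scatter), is beyond the scatter and is the only information on how the aryl group on the ring nitrogen matters.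

Compound 3 `O=C(O)c1ccc(COc2ccc(/C=C3\SC(=S)N(c4cccc(C(F)(F)F)c4)C3=O)cc2)cc1` is not yet measured. It differs from compound 2 by 3-(trifluoromethyl)phenyl in place of 4-methoxyphenyl on an amide-type nitrogen in a ring. Among the measured compounds shown here, no measured step covers a trifluoromethyl group at this position, so the single step from compound 1 to compound 2 bears only loosely on it: it shows that changing the aryl on that nitrogen can move the number by a large amount in either direction. Compound 2 stands at the weak end, so the estimate for compound 3 is expected to lie at or modestly below that limit, with wide uncertainty, and the expected step is an at least 1.2-fold lower number from compound 2 to compound 3 (0.09 log units; that floor lies within the scatter). The estimated value for compound 3 in this assay is 8000 nM, within 2000 nM to 30000 nM.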

Compound 3, inhibition constant: > 10000 nM
Compound 3 was reported as a limit (the forecaster's own chance of this, stated with the estimate: 50%); middle value at least 1.2-fold (0.09 log units) from the limit.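

In this assay compound 3 gives > 10000 nM, which is a limit of the assay and not a number. Placing 3-(trifluoromethyl)phenyl on the ring nitrogen instead of 2-methoxyphenyl gives an at least 5.0-fold higher number from compound 1 to compound 3 (0.69 log units; beyond the scatter), so a second aryl replacement at this position also loses readable inhibition, and compound 1 remains the only compound of the three with a measured number: the limit of > 10000 nM in this assay, at which 2 of the 3 values shown sit. The step between compound 2 and compound 3 cannot be read, and no order between 4-methoxyphenyl and 3-(trifluoromethyl)phenyl follows from two limits.

As far as these compounds go, it remains open whether the readable number of compound 1 depends on the methoxy group itself or on where it sits on the aryl ring, a question that 3-methoxyphenyl and 2-(trifluoromethyl)phenyl on the same nitrogen would separate. Also open, from the compounds shown here alone, is how an unsubstituted phenyl or a 2-aminophenyl group at this position would compare with compound 1, and whether any aryl group there can give stronger inhibition than 2-methoxyphenyl.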